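Swapping a Fluorophenyl for a Cyanophenyl: Expected Cytotoxicity

A few compounds are considered here, and "the series" means these few. Any claim that something is new, unique, unknown or untested is made for them only; others in the source may bear on it.

Measured so far in an ADME assay on MT4 cells (Homo sapiens) for cytotoxicity, read by MTT assay, with a stated time of 4 days; a higher number here means that more compound is tolerated, a lower number that less compound is tolerated:
- compound 1, `Cc1cc(-c2cc(Cl)cc(Cl)c2)cc(C)c1Nc1ccnc(Nc2ccc(C#N)cc2)n1`: 4290 nM
- compound 2, `Cc1cc(-c2cccc(F)c2)cc(C)c1Nc1ccnc(Nc2ccc(C#N)cc2)n1`: 4120 nM
- compound 3, `Cc1cc(-c2ccccc2F)cc(C)c1Nc1ccnc(Nc2ccc(C#N)cc2)n1`: 2120 nM

Compound 3 gives the lowest of the three numbers in this assay. The step of a 1.9-fold lower number from compound 2 to compound 3 (0.29 log units; within the scatter) stays within the scatter, while the step of a 2.0-fold lower number from compound 1 to compound 3 (0.31 log units; beyond the scatter) reaches beyond it, so only the latter reaches beyond the scatter, and compound 3 cannot be called the least tolerated outright.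

Compound 4, `Cc1cc(-c2cccc(C#N)c2)cc(C)c1Nc1ccnc(Nc2ccc(C#N)cc2)n1`, has not been measured. It differs from compound 3 as follows: 3-cyanophenyl in place of 2-fluorophenyl on an aromatic carbon.

Within the data shown here, two measured steps bear on it. The change from compound 1 to compound 2, a 1.0-fold lower number from compound 1 to compound 2 (0.02 log units; within the scatter), shows that swapping one ring substituent for another at this position can leave the number essentially unchanged. The step of a 1.9-fold lower number from compound 2 to compound 3 (0.29 log units; within the scatter) shows a modest shift that stays within the scatter. The entering 3-cyanophenyl has not been seen here, so the expectation rests on this narrow range. Compound 4 is therefore expected to sit near compound 3, with a step of a 1.4-fold higher number from compound 3 to compound 4 (0.15 log units; within the scatter) that stays within the scatter. The estimated value for compound 4 in this assay is 3000 nM, within a range from 1400 nM to 6500 nM.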

Compound 4, half-maximal cytotoxic concentration: 920 nM
Compound 4: middle estimate off by 3.3-fold (0.51 log units), on the high side, outside the stated range (below it).
By their numbers in this assay, from the lowest: compound 4; then compounds 3, 2 and 1 (each within the scatter of the next, the first and the last beyond it).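

In this assay, among these compounds, this position matters more than the earlier compounds suggested, with a 2.3-fold lower number from compound 3 to compound 4 (0.36 log units; beyond the scatter) when 3-cyanophenyl enters in place of 2-fluorophenyl. Cyano in place of fluoro gives a 4.5-fold lower number from compound 2 to compound 4 (0.65 log units; beyond the scatter) and 3-cyanophenyl in place of 3,5-dichlorophenyl gives a 4.7-fold lower number from compound 1 to compound 4 (0.67 log units; beyond the scatter), both larger than any step among the three earlier compounds. With all three steps beyond the scatter, compound 4 is the least tolerated of the four, so a change here can clearly lower the number rather than leave it nearly flat.

Nothing available gives a reason for this drop. Going by these compounds, it also remains open whether the lower number is particular to the nitrile, or whether an amine or a carboxylic acid on this ring would lower it as well.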